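The source may hold more compounds than are shown below. What is called first, only, known or untested is meant among the compounds shown, and "the series" means these compounds.

Measured so far in an assay on isolated protein for inhibition of NUAK family SNF1-like kinase 2 (Homo sapiens), read by ADP-Glo, with a stated time of 60 min, tested at 10 uM, in the presence of a further agent that is not named here; on this read-out lower numbers stand for less inhibition and higher numbers for more inhibition at the one concentration tested (going by the name of the read-out):
- compound 1 `CCC(=O)Nc1cccc(Oc2nc(Nc3ccc(N4CCC(OC)CC4)cc3OC)ncc2Cl)c1`: "not active" (no number reported)
- compound 2 `CCC(=O)Nc1cccc(Oc2nc(Nc3ccc(N4CCC(OC)CC4)cc3)ncc2Cl)c1`: 53.4%
- compound 3 `CCC(=O)Nc1cccc(Oc2nc(Nc3ccc(N4CCC(C)CC4)cc3OC)ncc2Cl)c1`: "not active" (no number reported)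

Among the compounds with values here, compound 2 carries the only number in this set; for compound 1 and compound 3 the read-out gives no single figure, each of them is only reported as not active. Within the data shown here, compound 2 therefore stands alone as the reference point, and no step between measured compounds can be drawn from these entries.

Compound 4 `CCC(=O)Nc1cccc(Oc2nc(Nc3ccc(N(C)C)cc3)ncc2Cl)c1` is not yet measured. It differs from compound 2 in one place: dimethylamino in place of 4-methoxypiperidin-1-yl on an aromatic carbon.

Among the measured compounds shown here, with no measured step of this kind available, the expectation for compound 4 rests on compound 2 alone, whose value is 53.4%. A loss of some size is expected, a number 15.4 percentage points lower from compound 2 to compound 4 (beyond the scatter), possibly just beyond the scatter. The estimate for compound 4 in this assay is 38%, with a range from 12% to 62%.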

Compound 4, a percentage reported as inhibition, at one concentration (the size of the read-out at that concentration, not a potency): 31.7%
The estimate for compound 4 lay 6.3 percentage points above the measured number; low and high end bracket the measured number.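

In this assay, within the data shown here, dimethylamino in place of 4-methoxypiperidin-1-yl gives a number 21.7 percentage points lower from compound 2 to compound 4 (beyond the scatter) and is the only measured step at this position. A ring at this position is therefore not required for a numerical reading at the one concentration tested, but the open-chain group retains less inhibition in this pair. No available measurement accounts for the step. On these data alone, it remains open whether the loss tracks the ring or its methoxy group. Piperidin-1-yl, morpholin-4-yl or diethylamino at this position would help separate those two parts.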